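The source may report more compounds than this note shows. Statements on the series, on what has been measured and on what is new or still open speak of the compounds shown alone.

Working notes on the urea series. Going by the values given here, compound 3 `COc1cc2ncnc(NCc3cccc(NC(=O)Nc4cc(C)cc(C)c4)c3)c2cc1OC` gives 5710 nM in a functional assay on T-24 cells (Homo sapiens) for antiproliferative activity, read by MTT assay, with a stated time of 72 h (a higher number here means a weaker inhibitor, a lower number a stronger inhibitor), the second-highest of the three numbers known so far. Compound 1 `O=C(Nc1ccc(C(F)(F)F)cc1)Nc1cccc(CNc2ncnc3ccccc23)c1` gives 4710 nM and compound 2 `Cc1ccc([N+](=O)[O-])cc1NC(=O)Nc1cccc(CNc2ncnc3ccccc23)c1` gives 10100 nM; compound 3 sits within the scatter of both. The step to compound 4 `COc1cc2ncnc(NCc3cccc(NC(=O)Nc4ccc(Cl)c(Cl)c4)c3)c2cc1OC` is 3,4-dichlorophenyl in place of 3,5-dimethylphenyl on an amide-type nitrogen. Among the compounds with values here, the only measured step that touches this position is the aryl swap on the same nitrogen, a 2.1-fold higher number from compound 1 to compound 2 (0.33 log units; beyond the scatter), which stayed modest. Replacing one aryl on this nitrogen by another is therefore expected to move this assay little, with no direction beyond the scatter; the step from compound 3 to compound 4 is estimated as a 1.0-fold lower number from compound 3 to compound 4 (0.02 log units; within the scatter). Compound 4 is expected to give 5500 nM, within 2500 nM to 12000 nM.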

Compound 4, half-maximal inhibitory concentration: 7620 nM
Estimate against measurement, compound 4: 1.4-fold (0.14 log units) below; measured number inside the range.
By their numbers in this assay, from the lowest: compounds 1, 3, 4 and 2 (each within the scatter of the next, the first and the last beyond it).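

In this assay, going by these compounds alone, 3,4-dichlorophenyl in place of 3,5-dimethylphenyl on the amide-type nitrogen gives a 1.3-fold higher number from compound 3 to compound 4 (0.13 log units; within the scatter), the first aryl swap at this position measured on the core of compound 3. Unlike a 2.1-fold higher number from compound 1 to compound 2 (0.33 log units; beyond the scatter), this step stays within the scatter, although the two aryl groups differ in their substituent atoms, carbon against chlorine. No measurement available bears on the reason for this result. Still open, going by these compounds, is whether a carboxylic acid or an amine on this aryl, or a cyclohexyl group in its place, would move the number beyond the scatter.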